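Fluoro to methyl on the compound 3 scaffold

The source may hold more compounds than are shown below. What is called first, only, known or untested is meant among the compounds shown, and "the series" means these compounds.

In an ADME assay on HuhET cells (Homo sapiens) for cytotoxicity, read by thymidine incorporation (a lower number here means that less compound is tolerated, a higher number that more compound is tolerated), compound 1 (`COC(=O)N[C@H](C(=O)N1C[C@@H](C)C[C@H]1c1nc2cc(-c3ccc(-c4cc5[nH]c([C@@H]6C[C@H](C)CN6C(=O)[C@@H](NC(=O)OC)C(C)C)nc5s4)cc3)ccc2[nH]1)C(C)C`) gives > 20000 nM as a limit of the assay. Compound 2 (`COC(=O)N[C@H](C(=O)N1C[C@@H](C)C[C@H]1c1cn2ccc(-c3ccc(-c4cc5[nH]c([C@@H]6C[C@H](C)CN6C(=O)[C@@H](NC(=O)OC)C(C)C)nc5s4)cc3)cc2n1)C(C)C`) gives a true number of 15300 nM in the same read-out. Compound 3 (`COC(=O)N[C@H](C(=O)N1C[C@@H](C)C[C@H]1c1ncc(-c2ccc(-c3ccc(-c4cc5[nH]c([C@@H]6C[C@H](C)CN6C(=O)[C@@H](NC(=O)OC)C(C)C)nc5s4)c(F)c3)cc2)[nH]1)C(C)C`) gives > 20000 nM as a limit too, and no number. Compound 3 thus stands at the limit of > 20000 nM in this assay, at which 2 of the 3 values shown sit, in these notes. Compound 4 (`COC(=O)N[C@H](C(=O)N1C[C@@H](C)C[C@H]1c1ncc(-c2ccc(-c3ccc(-c4cc5[nH]c([C@@H]6C[C@H](C)CN6C(=O)[C@@H](NC(=O)OC)C(C)C)nc5s4)c(C)c3)cc2)[nH]1)C(C)C`) has methyl in place of fluoro on an aromatic carbon ortho to a large group and meta to a large group. Within the data shown here, no measured pair shows this change alone. In this assay the estimated step of an at least 1.1-fold lower number from compound 3 to compound 4 (0.04 log units; that floor lies within the scatter) is expected to stay within the usual scatter, with no direction favoured. For compound 4 the expected value is 18000 nM with an estimated range from 9000 nM to 30000 nM and a report as a limit is likely.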

Compound 4, half-maximal cytotoxic concentration: > 20000 nM
Compound 4 ended at the assay's limit (the forecaster's own chance of this, stated with the estimate: 60%); middle value at least 1.1-fold (0.04 log units) away from the limit.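

Compound 3 and compound 4 both end at a limit in this assay, so the change from fluoro to methyl gives no readable step: the limit of > 20000 nM in this assay, at which 3 of the 4 values shown sit.

The compounds shown leave open how far either compound lies from that limit, and whether this change shifts the read-out at all.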